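Tertiary alcohol in place of carbamoyl on a shared core

This account rests on a few compounds, and the source may have more. Where it says the series, first, only, none or still open, it means among the compounds named here.

compound 1 `Brc1ccc2ccn(CCN3CCNCC3)c2c1` — 61%
compound 2 `CN1CCCN(CCn2ccc3cccc(Br)c32)CC1` — 18%
compound 3 `CN1CCCN(CCn2ccc3ccc(C(N)=O)cc32)CC1` — 33%

Three compounds have been run in an assay on HEK293 cells for binding affinity to 5-hydroxytryptamine receptor 7 (Homo sapiens), read by radioligand binding, tested at 1 uM; a higher number here means more inhibition at the concentration tested (going by the name of the read-out), a lower number less inhibition. Compound 3 gives 33%, the second highest of the three numbers. Its nearest neighbour is compound 2, whose number is lower by a margin beyond the scatter, and the furthest is compound 1, whose number is higher by a margin beyond the scatter. Compound 1 and compound 2 differ from each other and from compound 3 in more than one place, so none of these pairs isolates a single change.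

Compound 4 `CN1CCCN(CCn2ccc3ccc(C(C)(C)O)cc32)CC1` is the next candidate. It differs from compound 3 in one place: 1-hydroxy-1-methylethyl in place of carbamoyl on an aromatic carbon. Among the compounds with values here, no measured pair shows what this exchange alone does, so the expectation rests on compound 3 alone and on the modest size of the group exchanged. The step of a number 3 percentage points lower from compound 3 to compound 4 (within the scatter) is expected to be small, within the scatter, with no clear direction. Compound 4 is therefore estimated at 30%, with a range from 10% to 52%.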

Compound 4, a percentage reported as inhibition, at one concentration (the size of the read-out at that concentration, not a potency): 6%
Compound 4: middle estimate off by 24 percentage points, on the high side; measured number below the stated range.
By their numbers in this assay, from the lowest: compound 4; then compound 2; then compound 3; then compound 1.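

In this assay, within the data shown here, the exchange of carbamoyl for 1-hydroxy-1-methylethyl on this aromatic carbon is the first change in a single place that can be read, and it gives a number 27 percentage points lower from compound 3 to compound 4 (beyond the scatter). The position is therefore not indifferent to what it carries. The two groups have the same count of hydrogen-bond donors and of acceptors, and neither has a ring or a net charge, yet the read-out separates them. No measured property bears on this result, and so no account of it can be offered here.

On these data alone, a hydroxymethyl group or a carboxylic acid in this place remains open, and with it the question of whether the fall follows the tertiary alcohol as a whole or its methyl groups. Compound 1 and compound 2 differ from compound 4 in more than one place, and their steps cannot be read.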